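The compounds below may be only part of what the source reports. "The series", "measured", "known", "first", "only" and "open" are said of these compounds alone.

The series shares the core that appears in compound 1 `Cc1ccccc1NC(=O)Nc1ccc2c(c1)COC2=O`, a urea that gives 900 nM in a functional assay on cells (T-cell, Mus musculus) for inhibition; on this read-out lower numbers stand for stronger inhibition and higher numbers for weaker inhibition. Two oxamides sit on the same core: compound 2 `O=C(Nc1ccccc1)C(=O)Nc1ccc2c(c1)COC2=O`, which in this assay gives 36100 nM, and compound 3 `CC(C)(C)NC(=O)C(=O)Nc1ccc2c(c1)COC2=O`, which in this assay gives 3400 nM. Among the three numbers compound 3 stands second highest, with compound 1 nearest and compound 2 furthest from it. For the measured compounds named here, the one step within the measured set, an 11-fold lower number from compound 2 to compound 3 (1.03 log units; beyond the scatter), is the only one that differs in a single place, and it is large.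

Compound 4 `O=C(Nc1ccc(F)cc1)C(=O)Nc1ccc2c(c1)COC2=O` differs from compound 3 in the following way: 4-fluorophenyl in place of tert-butyl on an amide-type nitrogen. This change runs the measured step backwards in kind, since it puts an aromatic ring back where tert-butyl had replaced phenyl. The step of an 11-fold lower number from compound 2 to compound 3 (1.03 log units; beyond the scatter) therefore bears directly on it, and its reverse points to a number well above that of compound 3. Compound 2 sits on the far side of this move at 36100 nM, and compound 4 carries only a fluorine more than compound 2, so a number in that region is expected. The step is expected to be an 8.8-fold higher number from compound 3 to compound 4 (0.95 log units; beyond the scatter), beyond the scatter. For compound 4 the estimate in this assay is 30000 nM, with a range from 10000 nM to 80000 nM.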

Compound 4, half-maximal inhibitory concentration: 570 nM
For compound 4 the middle estimate is 53-fold (1.72 log units) above the measured one; the measured number lies below the stated range.
By their numbers in this assay, from the lowest: compounds 4 and 1 (each within the scatter of the next); then compound 3; then compound 2.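

In this assay, an aromatic ring on the amide-type nitrogen does not by itself give the weaker number, as shown by a 6.0-fold lower number from compound 3 to compound 4 (0.78 log units; beyond the scatter); compound 2 goes against this, since its unsubstituted phenyl gives the highest number of the oxamides. What separates the two aromatic compounds is a single change, fluoro in place of hydrogen on an aromatic carbon, which gives a 63-fold lower number from compound 2 to compound 4 (1.80 log units; beyond the scatter), so that compound 3 now lies between them, with each of the two beyond the scatter from it. Nothing available accounts for why this one substitution matters so much here.

The compounds shown leave open whether the step belongs to fluoro alone, or whether chloro, methoxy, a nitrile or an amine in place of the same hydrogen would also give a number close to that of compound 4. They also leave open whether the 4-fluorophenyl group would have a comparable effect on a urea such as compound 1, where the oxamide is absent.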